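The source may report more compounds than this note shows. Statements on the series, on what has been measured and on what is new or still open speak of the compounds shown alone.

Measured compounds:
compound 1, `C=C[C@@]1(O)[C@@H](CO)O[C@@H](n2ccc(N)nc2=O)[C@@H]1O`, 60800 nM
compound 2, `CC#C[C@@]1(O)[C@@H](CO)O[C@@H](n2ccc(N)nc2=O)[C@@H]1O`, 24500 nM

Both numbers come from a functional assay on L1210 cells (Mus musculus), read by MTT assay; a higher number here means a weaker inhibitor, a lower number a stronger inhibitor. Among the measured compounds shown here, compound 2 gives the lowest of the two numbers; the only other compound, compound 1, lies a 2.5-fold lower number from compound 1 to compound 2 (0.39 log units; beyond the scatter) away, a modest step that still exceeds the usual scatter. Compound 3, `Nc1ccn([C@@H]2O[C@H](CO)[C@](O)(C3CC3)[C@H]2O)c(=O)n1`, has not yet been measured. It differs from compound 2 in one place: cyclopropyl in place of prop-1-yn-1-yl on a saturated ring carbon. For the measured compounds named here, no measured step covers such an exchange: the only step at hand, a 2.5-fold lower number from compound 1 to compound 2 (0.39 log units; beyond the scatter), swaps one unsaturated three-carbon chain for another, whereas here a chain gives way to a small ring. That step is modest, so the change to compound 3 is expected to be modest too, in either direction, and may well stay within the scatter. The estimate for compound 3 in this assay is therefore 40000 nM, with a range from 12000 nM to 130000 nM, meaning an expected 1.6-fold higher number from compound 2 to compound 3 (0.21 log units; within the scatter).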

Compound 3, half-maximal inhibitory concentration: > 350000 nM
Compound 3: a limit, no number; the forecaster's own chance of this, stated with the estimate: 10%; at least 8.7-fold (0.94 log units) between middle value and limit.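

In this assay compound 3 stands at a limit of the assay and not at a number: the limit of > 350000 nM in this assay, at which 1 of the 3 values shown sits. Even so, the steps can be read in one direction: cyclopropyl in place of prop-1-yn-1-yl gives an at least 14-fold higher number from compound 2 to compound 3 (1.15 log units; beyond the scatter), and cyclopropyl in place of vinyl gives an at least 5.7-fold higher number from compound 1 to compound 3 (0.76 log units; beyond the scatter). At this saturated ring carbon, the heavy-atom count of a group therefore does not settle the outcome: prop-1-yn-1-yl and cyclopropyl each have 3 heavy atoms, yet this exchange is large, whereas the earlier exchange of vinyl for prop-1-yn-1-yl, a 2.5-fold lower number from compound 1 to compound 2 (0.39 log units; beyond the scatter), was modest.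

From the compounds shown here alone, how far the step to compound 3 really reaches stays open. So does whether an open saturated chain such as ethyl or propyl, or an amine, at this carbon would sit closer to compound 2 or to compound 3.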